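Shifting a Methoxy Group on a Bis-Benzylidene Cyclohexanone Scaffold

The source may report more compounds than this note shows. Statements on the series, on what has been measured and on what is new or still open speak of the compounds shown alone.

Compound 1 `COc1cccc(/C=C2\CCC/C(=C\c3cccc(OC)c3OC)C2=O)c1` gives 16400 nM in an ADME assay on NHDF cells (Homo sapiens) for cytotoxicity, read by MTT assay, with a stated time of 72 h; a lower number here means a stronger inhibitor, a higher number a weaker inhibitor. Compound 2 `COc1ccc(/C=C2\CCC/C(=C\c3cccc(OC)c3OC)C2=O)cc1` gives 43500 nM in this assay. Compound 3 `COc1cccc(/C=C2\CCC/C(=C\c3ccc(OC)c(OC)c3)C2=O)c1` gives 11600 nM in this assay.

Compound 3 carries the lowest number of the three, yet its gap to compound 1 lies within the scatter, so the two cannot be ordered; only compound 2 stands clearly apart. The difference between the core of compound 1 and that of compound 3 is not broken down here.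

Compound 4 `COc1ccc(/C=C2\CCC/C(=C\c3ccc(OC)c(OC)c3)C2=O)cc1` has not yet been measured. It differs from compound 3 by 4-methoxyphenyl in place of 3-methoxyphenyl on a double-bonded chain carbon bound to a double-bonded ring carbon, and this is the same change that separates compound 1 from compound 2, namely (4-methoxyphenyl in place of 3-methoxyphenyl on a double-bonded chain carbon bound to a double-bonded ring carbon), where the step was a 2.7-fold higher number from compound 1 to compound 2 (0.42 log units; beyond the scatter). Going by the values given here, the same step is expected here, because a 2.7-fold higher number from compound 1 to compound 2 (0.42 log units; beyond the scatter) is the only example of this change, the expectation is a 2.7-fold higher number from compound 3 to compound 4 (0.43 log units; beyond the scatter). Compound 4 is therefore estimated at 31000 nM, with a likely range from 15000 nM to 65000 nM.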

Compound 4, half-maximal inhibitory concentration: 30900 nM
For compound 4 the middle estimate is 1.0-fold (0.00 log units) above the measured one; measured number inside the range.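

With 4-methoxyphenyl in place of 3-methoxyphenyl on a double-bonded chain carbon bound to a double-bonded ring carbon, this assay shows a 2.7-fold higher number from compound 3 to compound 4 (0.43 log units; beyond the scatter). The change therefore carried over from the core of compound 1 to the core of compound 3 with no difference in size that can be told apart: the same change on two cores in this assay, a 2.7-fold higher number (0.42 log units; beyond the scatter) from compound 1 to compound 2 and a 2.7-fold higher number (0.43 log units; beyond the scatter) from compound 3 to compound 4, 1.0-fold (0.00 log units) apart, within the scatter of two such steps. Going by these compounds alone, this rests on only two cores in a single assay, so it does not show that the step would hold on other cores, nor does it explain its size.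

From the compounds shown here alone, all four compounds carry only methoxy groups on their phenyl rings, so the effect of a hydroxyl or a dimethylamino group in that place remains open. Going by these compounds, whether the step appears in any other assay also remains open.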